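Two Inactive Amides and a Dichlorophenyl Analogue

The source may hold more compounds than are shown below. What is called first, only, known or untested is meant among the compounds shown, and "the series" means these compounds.

Compound 1 `O=C(Nc1ccc(Cl)c(-c2nnc3c(Cl)cccn23)c1)c1cccnc1`: in a functional assay on MDA-MB-231 cells (Homo sapiens) for antiproliferative activity, read by MTT assay, with stated times of 72 h and 4 h (on this read-out higher numbers stand for weaker inhibition and lower numbers for stronger inhibition), compound 1 gives > 100000 nM, which is a limit of the assay and not a number.
Compound 2 `O=C(Nc1ccc(Cl)c(-c2nnc3c(Cl)cccn23)c1)c1ccc(C(F)(F)F)cc1F`: in this assay compound 2 gives > 100000 nM, again a limit of the assay.

Both measured compounds share the same core and differ only in the aromatic group attached to the amide carbonyl. Compound 1 stands at the limit, so its place among the numbers cannot be fixed more closely; the same holds for compound 2, as the limit of > 100000 nM in this assay, at which 2 of the 2 values shown sit, shows. Compound 3 `O=C(Nc1ccc(Cl)c(-c2nnc3c(Cl)cccn23)c1)c1ccc(Cl)cc1Cl` has not yet been measured. It differs from compound 1 by 2,4-dichlorophenyl in place of pyridin-3-yl on a carbonyl carbon. Within the data shown here, no step between two measured compounds is available, so the size of the step in this assay can only be estimated. Compound 2, which also carries a substituted phenyl on the carbonyl, gives > 100000 nM in this assay, a limit. The step from compound 1 to compound 3 is therefore expected to be a number no higher from compound 1 to compound 3 (the limit leaves the size open), none beyond the scatter. For compound 3 the estimated value in this assay is 100000 nM, in an expected range from 30000 nM to 300000 nM, most likely reported again as a limit.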

Compound 3, half-maximal inhibitory concentration: > 100000 nM
Compound 3: no number, only a limit; the forecaster's own chance of this, stated with the estimate: 80%; the middle value lies on the limit itself.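

In this assay compound 3 gives > 100000 nM as a limit of the assay and not a number. Among these compounds, compound 1 also stands at a limit, so no step between compound 1 and compound 3 can be read. Still open, as far as these compounds go, is whether any group on the carbonyl of the shared core gives a number in this assay at all.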